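The source may hold more compounds than are shown below. What is called first, only, known or untested is meant among the compounds shown, and "the series" means these compounds.

The measured compounds and their values:

Compound 1, `COC1=C(C)C(=O)C(CCCCCCCCCCn2cc(C[C@H](O)COCCOC[C@@H](O)Cc3ccc(-c4ccccc4)cc3)nn2)=C(C)C1=O`, in a functional assay on SGC-7901 cells (Homo sapiens) for inhibition, read by MTT assay, with a stated time of 72 h (a higher number here means a weaker inhibitor of growth, a lower number a stronger inhibitor of growth), compound 1 gives 505 nM.
Compound 2, `COC1=C(OC)C(=O)C(CCCCCCCCCCn2cc(C[C@H](O)COCCOC[C@@H](O)Cc3ccc(-c4ccccc4)cc3)nn2)=C(C)C1=O`, in this assay compound 2 gives 3800 nM.
Compound 3, `O[C@H](COCCOC[C@@H](O)Cc1cn(-c2cccnc2)nn1)Cc1ccc(-c2ccccc2)cc1`, in this assay compound 3 gives 29800 nM.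

Compound 3 stands highest of the three numbers in this assay: its value lies above that of compound 2, which is the nearest, and further still above that of compound 1. Compound 3 differs from the other two in lacking the long chain and the quinone-type ring that those carry on the triazole nitrogen, bearing a small aromatic ring there instead.

The unmeasured compound 4, `O[C@H](COCCOC[C@@H](O)Cc1cn(-c2ccc3[nH]ccc3c2)nn1)Cc1ccc(-c2ccccc2)cc1`, is reached from compound 3 by a single change: 1H-indol-5-yl in place of pyridin-3-yl on an aromatic nitrogen.

Only one measured step exists among these compounds, a 7.5-fold higher number from compound 1 to compound 2 (0.88 log units; beyond the scatter), and it concerns a change on the ring of compound 1, far from the triazole nitrogen, so it does not bear on the change from compound 3 to compound 4. Within the data shown here, the data hold no step in which a group on the triazole nitrogen is exchanged for another. With nothing to point in either direction, a step for compound 4 of no more than the scatter is expected, a 1.4-fold lower number from compound 3 to compound 4 (0.13 log units; within the scatter).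

Compound 4 is therefore estimated at 22000 nM in this assay, with a range from 6000 nM to 70000 nM.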

Compound 4, concentration for 50% growth inhibition: 45600 nM
Beside the measured number, compound 4's estimate is 2.1-fold (0.32 log units) below it; measured number inside the range.
By their numbers in this assay, from the lowest: compound 1; then compound 2; then compounds 3 and 4 (each within the scatter of the next).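

In this assay, among these compounds, placing 1H-indol-5-yl instead of pyridin-3-yl on the aromatic nitrogen of the five-membered aromatic ring with 3 nitrogen gives a 1.5-fold higher number from compound 3 to compound 4 (0.18 log units; within the scatter), the first exchange at this position that can be read directly. The entering group has a five-membered aromatic ring in addition to a six-membered one, and it carries a hydrogen-bond donor where the leaving group carries a hydrogen-bond acceptor, yet the two compounds remain within the scatter of each other, so this pair of aromatic groups cannot be told apart in this read-out. No measured evidence is available that bears on this result.

The compounds shown leave open what a plain phenyl ring, or an aromatic ring carrying an amine or a carboxylic acid, would give on that nitrogen in place of these two groups. They also leave open what a plain alkyl chain, without the quinone-type ring at its end, would give at this position compared with compound 3 and compound 4.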